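N-substituent change on a beta-lactam acid amidase inhibitor

The source may hold more compounds than are shown below. What is called first, only, known or untested is meant among the compounds shown, and "the series" means these compounds.

Measured compounds:
- compound 1, `CN1C[C@H](NC(=O)OCCCCC2CCCCC2)C1=O`: 1980 nM
- compound 2, `CCOCCON1C(=O)[C@@H](NC(=O)OCCCCC2CCCCC2)[C@@H]1C`: 187 nM

Both compounds were tested in an assay on HEK293 cells for inhibition of N-acylethanolamine-hydrolyzing acid amidase (Homo sapiens), read by fluorescence, with stated times of 10 min and 50 min; on this read-out lower numbers stand for stronger inhibition and higher numbers for weaker inhibition. Compound 1 gives 1980 nM, and compound 2 gives 187 nM. Of these two numbers, compound 2 has the lower one, and the gap to compound 1 is beyond the scatter of repeated measurements, so compound 2 is the stronger inhibitor of the pair.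

Compound 3, `C[C@H]1[C@H](NC(=O)OCCCCC2CCCCC2)C(=O)N1OCCCCc1ccccc1`, has not yet been measured. It differs from compound 2 in one place: phenethyl in place of ethoxy on a saturated chain carbon, two bonds along the chain from an oxygen on an unsaturated carbon. Whether this exchange helps or hurts cannot be read from the two measured compounds, because neither of them carries such a group in that position. With no guidance from a measured step, the step from compound 2 to compound 3 is expected to be small, a 1.4-fold lower number from compound 2 to compound 3 (0.16 log units; within the scatter), and not clearly beyond the scatter in either direction. On that basis compound 3 is expected to give about 130 nM in this assay, with a plausible range from 30 nM to 600 nM.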

Compound 3, half-maximal inhibitory concentration: 1240 nM
The estimate for compound 3 lay 9.5-fold (0.98 log units) below the measured number; the measured number lies above the stated range.
By their numbers in this assay, from the lowest: compound 2; then compounds 3 and 1 (each within the scatter of the next).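

In this assay, putting phenethyl in place of ethoxy on a saturated chain carbon, two bonds along the chain from an oxygen on an unsaturated carbon, gives a 6.6-fold higher number from compound 2 to compound 3 (0.82 log units; beyond the scatter), so inhibition at this position depends on the group it carries, and this larger group weakens it. The exchange alters several things at once: the oxygen of the ethoxy leaves, the heavy-atom count rises, and a six-membered aromatic ring enters, so this single step cannot separate their contributions. Nothing measured here explains the weaker inhibition.

The compounds shown leave open how an all-carbon chain without a ring, such as hexyl, would behave at this position. They also leave open whether an ether oxygen kept within a longer chain, or an amine at its end, would restore inhibition.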